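A few compounds are considered here, and "the series" means these few. Any claim that something is new, unique, unknown or untested is made for them only; others in the source may bear on it.

Of the compounds shown here, three built on a shared core have been tested in a functional assay on HT-1080 cells (Homo sapiens) for cytotoxicity, read by MTT assay, with a stated time of 72 h; on this read-out higher numbers stand for weaker inhibition and lower numbers for stronger inhibition. Compound 1 `COc1cccc(/C=C2\CCC/C(=C\c3cccc(O)c3)C2=O)c1OC` gives 8500 nM and compound 3 `COc1cc(/C=C2\CCC/C(=C\c3cccc(OC)c3OC)C2=O)cc(OC)c1` gives 4500 nM, and these two values lie within the usual scatter of each other, so the data cannot separate them. Compound 2 `COc1ccc(/C=C2\CCC/C(=C\c3cccc(OC)c3OC)C2=O)c(OC)c1` gives no number, only a limit of the assay, > 20000 nM. Compound 1 thus stands together with compound 3 as one of the two compounds with a true number.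

The next step leads to compound 4 `COc1cc(/C=C2\CCC/C(=C\c3cccc(OC)c3OC)C2=O)ccc1O`, which has not yet been measured. The change is 4-hydroxy-3-methoxyphenyl in place of 3-hydroxyphenyl on a double-bonded chain carbon bound to a double-bonded ring carbon. Within the data shown here, no measured pair here differs in one place only, so there is no direct precedent. With compound 3 at 4500 nM and compound 1 at 8500 nM as the closest guides, no change beyond the scatter is expected in this assay. The estimated step of a 1.4-fold lower number from compound 1 to compound 4 (0.15 log units; within the scatter) reflects that expectation. Compound 4 is expected at 6000 nM, with an estimated range from 2000 nM to 18000 nM.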

Compound 4, half-maximal inhibitory concentration: 5900 nM
The estimate for compound 4 lay 1.0-fold (0.01 log units) above the measured number, within the range that was stated.
By their numbers in this assay, from the lowest: compounds 3, 4 and 1 (each within the scatter of the next). At a limit, above all of these: compound 2.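

In this assay, among these compounds, the step at this place, a double-bonded chain carbon bound to a double-bonded ring carbon, is a 1.4-fold lower number from compound 1 to compound 4 (0.16 log units; within the scatter) and gives the first direct reading of a change in one place. Replacing 3-hydroxyphenyl with the larger 4-hydroxy-3-methoxyphenyl therefore leaves the read-out within the scatter, so this place accepts this swap without a measurable change in this assay. Nothing measured here offers a cause for this result.

The swap alters the hydroxyl position and adds a methoxy group together, so the compounds shown leave open what each alteration does alone, which 4-hydroxyphenyl at this place could help to separate. Also open, from the compounds shown here alone, is whether a phenyl ring carrying an amine or a carboxylic acid here would produce a step beyond the scatter.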